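The source may hold more compounds than are shown below. What is called first, only, known or untested is meant among the compounds shown, and "the series" means these compounds.

Compounds measured so far in a functional assay on DU-145 cells (Homo sapiens) for cytotoxicity, read by MTT assay, with a stated time of 48 h; on this read-out higher numbers stand for weaker inhibition and lower numbers for stronger inhibition:

Compound 1, `COC(=O)c1c(-c2cc3ccccc3oc2=O)nn(-c2ccccc2)c1C(=O)OC`: 30000 nM
Compound 2, `COC(=O)c1c(-c2cc3ccccc3oc2=O)nn(-c2cccc(Cl)c2)c1C(=O)OC`: 32000 nM

The two measured compounds share the same core and differ only on the phenyl ring. In this assay compound 1 gives 30000 nM while compound 2 gives 32000 nM. Compound 2 therefore stands level with compound 1 on the numbers shown: the step of a 1.1-fold higher number from compound 1 to compound 2 (0.03 log units; within the scatter) lies within the scatter of repeated measurements, so the two values cannot be told apart.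

Compound 3, `COC(=O)c1c(-c2cc3ccccc3oc2=O)nn(-c2cccc(F)c2)c1C(=O)OC`, is the next member of this pair. It differs from compound 2 in one place: fluoro in place of chloro on an aromatic carbon. Among the measured compounds shown here, the only measured step that bears on this change is the one at the same aromatic carbon, where a chloro replaced a hydrogen; that step, a 1.1-fold higher number from compound 1 to compound 2 (0.03 log units; within the scatter), was within the scatter. With a second halogen now replacing the first at that carbon, the expectation for compound 3 in this assay is a step of a 1.0-fold lower number from compound 2 to compound 3 (0.01 log units; within the scatter), that is, no change beyond the scatter. Compound 3 is thus estimated at 31000 nM, with a range from 15000 nM to 65000 nM.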

Compound 3, half-maximal inhibitory concentration: 37000 nM
For compound 3 the middle estimate is 1.2-fold (0.08 log units) below the measured one; the measured number falls inside the stated range.
By their numbers in this assay, from the lowest: compounds 1, 2 and 3 (each within the scatter of the next).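

In this assay, the exchange of one halogen for the other, 3-chlorophenyl to 3-fluorophenyl, gives a 1.2-fold higher number from compound 2 to compound 3 (0.06 log units; within the scatter), so the two halogens cannot be told apart at this aromatic carbon. Fluoro in place of hydrogen at that same carbon gives a 1.2-fold higher number from compound 1 to compound 3 (0.09 log units; within the scatter), which adds a second halogen to the earlier comparison of chloro with hydrogen and shows that neither halogen stands apart from hydrogen here. All three compounds therefore stand level at this position on the shared core, and nothing available offers an explanation for that result.

What the compounds shown leave open is whether any group at this carbon can move the number beyond the scatter, since hydrogen, chloro and fluoro are the only substituents compared there, and an amine, a carboxylic acid or a methoxy group might or might not stand apart from them. On these data alone, it also remains open whether the same halogens would behave alike on another carbon of this ring, or whether changes elsewhere on the shared core would matter more than this position does.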